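Working notes: from compound 2 to compound 3

The source may report more compounds than this note shows. Statements on the series, on what has been measured and on what is new or still open speak of the compounds shown alone.

For the measured compounds named here, in an ADME assay on L02 cells (Homo sapiens) for inhibition, read by CCK-8 assay, with a stated time of 48 h (a higher number here means a weaker inhibitor of growth, a lower number a stronger inhibitor of growth), compound 2 (`COc1ccccc1CNc1nc(Nc2ccc(N3CCN(C)CC3)cn2)ncc1Cl`) gives 25500 nM as the only actual number so far. Compound 1 (`Cc1ccc(CNc2nc(Nc3ccc(N4CCN(C)CC4)cn3)ncc2Cl)cc1`) reads > 100000 nM and that is a limit of the assay.

Compound 3 (`Cc1ccc(Nc2nc(Nc3ccc(N4CCN(C)CC4)cn3)ncc2Cl)cc1`) has 4-methylphenyl in place of 2-methoxybenzyl on a nitrogen on an aromatic ring. Going by the values given here, the only measured step bearing on this is an at least 3.9-fold lower number from compound 1 to compound 2 (0.59 log units; beyond the scatter) with 2-methoxyphenyl in place of 4-methylphenyl on a saturated chain carbon bound to a nitrogen on an aromatic ring. Among the compounds with values here, compound 3 regains 4-methylphenyl but lacks that saturated chain carbon, and no measured step covers this loss.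

A modest move to a higher number is therefore expected, an estimated 1.6-fold higher number from compound 2 to compound 3 (0.20 log units; within the scatter) in size. The estimate for compound 3 is 40000 nM (expected range 10000 nM to 100000 nM).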

Compound 3, concentration for 50% growth inhibition: 13900 nM
Compound 3: middle estimate off by 2.9-fold (0.46 log units), on the high side; low and high end bracket the measured number.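

In this assay, for the compounds shown here, 4-methylphenyl in place of 4-methylbenzyl on a nitrogen on an aromatic ring gives an at least 7.1-fold lower number from compound 1 to compound 3 (0.85 log units; beyond the scatter), the first step that removes only the saturated chain carbon. That step rests on a limit of the assay: the limit of > 100000 nM in this assay, at which 1 of the 3 values shown sits. The change to 4-methylphenyl from 2-methoxybenzyl gives a 1.8-fold lower number from compound 2 to compound 3 (0.26 log units; within the scatter), so this pair cannot be separated on this read-out.

Still open, from the compounds shown here alone, is how 2-methoxyphenyl reads on the same nitrogen without the saturated chain carbon. Also open, going by these compounds, is how a longer chain, such as 2-phenylethyl, or a carboxylic acid on the phenyl ring reads at this position.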